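Thiophene attachment point on a nucleoside scaffold

The source may hold more compounds than are shown below. What is called first, only, known or untested is meant among the compounds shown, and "the series" means these compounds.

Compound 1 `C#Cc1cn([C@@H]2O[C@H](CO)[C@@H](O)[C@H]2O)c2ncnc(C)c12`, compound 2 `Cc1nc(N)c2c(-c3cccs3)cn([C@@H]3O[C@H](CO)[C@@H](O)[C@H]3O)c2n1`, compound 3 `Cc1ncnc2c1c(-c1ccoc1)cn2[C@@H]1O[C@H](CO)[C@@H](O)[C@H]1O` and compound 4 `Cc1nc(N)c2c(-c3ccsc3)cn([C@@H]3O[C@H](CO)[C@@H](O)[C@H]3O)c2n1` all carry a shared core with one varied group on an aromatic carbon. In an ADME assay on MRC5 cells (Homo sapiens), read by MTT assay, with a stated time of 72 h (a lower number here means a stronger inhibitor, a higher number a weaker inhibitor), compound 1 gives 1440 nM and compound 3 gives 98300 nM. Among the compounds with values here, the only step between two measured compounds that differ in one place is a 68-fold higher number from compound 1 to compound 3 (1.83 log units; beyond the scatter). For compound 2 this assay reports no number, only a limit of > 100000 nM, as noted in the limit of > 100000 nM in this assay, at which 1 of the 3 values shown sits. Compound 4 differs from compound 2 by thiophen-3-yl in place of thiophen-2-yl on an aromatic carbon. Within the data shown here, no measured step concerns this exchange: the step from compound 1 to compound 3 replaces an ethynyl group by a furan-3-yl group, a different change, and gives no guide here. Among the measured compounds shown here, with compound 2 standing at the limit, compound 4 is expected to remain near that limit as well, with no step expected beyond the scatter. The expected step is a step that the limit leaves unreadable from compound 2 to compound 4. Compound 4 is therefore estimated at 150000 nM, within a range from 50000 nM to 500000 nM.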

Compound 4, half-maximal inhibitory concentration: > 100000 nM
Compound 4 ended at the assay's limit; the forecaster's own chance of this, stated with the estimate: 70%; the middle value is on the limit's open side.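

In this assay compound 4 gives > 100000 nM, a limit and not a number. Compound 2 also stands at a limit, and no step can be read between compound 2 and compound 4. The compounds shown leave open whether thiophen-2-yl and thiophen-3-yl differ at all in this assay.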